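The compounds below may be only part of what the source reports. "The series", "measured", "known", "first", "only" and "open" are said of these compounds alone.

Measured compounds in a functional assay (aorta) with Oryctolagus cuniculus as the target; a higher number here means a weaker inhibitor, a lower number a stronger inhibitor:
compound 1 `Fc1ccccc1Cn1nc(-c2ccco2)c2cccnc21` — 9300 nM
compound 2 `OCc1ccnc(-c2nn(Cc3ccccc3F)c3ncccc23)n1` — 1300 nM
compound 3 `Cc1cnc(-c2nn(Cc3ccccc3F)c3ncccc23)nc1N` — 675000 nM

Compound 3 stands highest of the three in this assay: the step of a 73-fold higher number from compound 1 to compound 3 (1.86 log units; beyond the scatter) and the step of a 520-fold higher number from compound 2 to compound 3 (2.72 log units; beyond the scatter) are both well beyond the scatter, while compound 2 sits lowest after the step of a 7.2-fold lower number from compound 1 to compound 2 (0.85 log units; beyond the scatter).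

Compound 4 `Nc1nc(-c2nn(Cc3ccccc3F)c3ncccc23)ncc1C1=CCCC1` keeps the core and the amino group of compound 3 and differs only as follows: cyclopent-1-en-1-yl in place of methyl on an aromatic carbon.

Going by the values given here, none of the measured steps touches this position; all three exchange the whole group on the aromatic carbon of the core, so no precedent for the size of a change at the methyl exists in this set. The expectation for compound 4 is therefore set near compound 3, with a wide range: an estimate of 300000 nM (range 40000 nM to 2000000 nM), a step of a 2.3-fold lower number from compound 3 to compound 4 (0.35 log units; beyond the scatter) that is expected to stay within uncertainty rather than rest on a measured trend.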

Compound 4, half-maximal inhibitory concentration: 836000 nM
Estimate against measurement, compound 4: 2.8-fold (0.45 log units) below, and the stated range covers the measured number.
By their numbers in this assay, from the lowest: compound 2; then compound 1; then compounds 3 and 4 (each within the scatter of the next).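

In this assay, cyclopent-1-en-1-yl in place of methyl on the aromatic carbon ortho to the amino group gives a 1.2-fold higher number from compound 3 to compound 4 (0.09 log units; within the scatter). Going by these compounds alone, this is the first step at this position, and the larger carbon-only ring leaves the number within the scatter, so the series shows no sensitivity here across these two groups. No available evidence explains this result.

On these data alone, it remains open whether a carboxylic acid or an amine on this carbon would move the number. Also open, as far as these compounds go, is how compound 4 would read without its amino group.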